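From Triazolyl to 4-Bromophenoxy on a Shared Core

The source may report more compounds than this note shows. Statements on the series, on what has been measured and on what is new or still open speak of the compounds shown alone.

In a functional assay on RAW264.7 cells (Mus musculus) for inhibition, read by Griess assay, with stated times of 3 h and 24 h (on this read-out higher numbers stand for weaker inhibition and lower numbers for stronger inhibition), compound 1 `C=C1CCC2[C@](C)(CO)[C@H](O)CC[C@@]2(C)[C@@H]1CCn1cncn1` gives > 100000 nM, which is a limit and not a measured number. Compound 2 `C=C1CCC2[C@](C)(CO)[C@H](O)CC[C@@]2(C)[C@@H]1CCn1cnc2c(N)ncnc21` gives > 100000 nM, also a limit. Compound 3 `C=C1CCC2[C@](C)(CO)[C@H](O)CC[C@@]2(C)[C@@H]1CCOc1ccc2ccc(=O)oc2c1` gives > 50000 nM, again a limit. Among the compounds with values here, compound 1 therefore has no exact position on this scale, and no compound in the set yet offers a measured step as a guide.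

Compound 4 `C=C1CCC2[C@](C)(CO)[C@H](O)CC[C@@]2(C)[C@@H]1CCOc1ccc(Br)cc1` keeps the core of compound 1 but has 4-bromophenoxy in place of 1H-1,2,4-triazol-1-yl on a saturated chain carbon, two bonds along the chain from a saturated ring carbon.

Within the data shown here, with no measured step available, only a modest move towards stronger inhibition in this assay is expected, and the result may well remain a limit. The expected step is an at least 2.2-fold lower number from compound 1 to compound 4 (0.34 log units; beyond the scatter). For compound 4, the estimated value is 45000 nM, with an expected range of 15000 nM to 100000 nM.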

Compound 4, half-maximal inhibitory concentration: 40300 nM
Beside the measured number, compound 4's estimate is 1.1-fold (0.05 log units) above it; the range from low to high includes it.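

Within the data shown here, compound 4 is the first compound here with a true measured number in this assay, so the saturated chain carbon, two bonds along the chain from a saturated ring carbon, can carry a group that gives a readable inhibition value. Among these compounds, putting 4-bromophenoxy in place of 1H-1,2,4-triazol-1-yl gives an at least 2.4-fold lower number from compound 1 to compound 4 (0.39 log units; beyond the scatter), the first step on this scale. That step is only a lower bound on the true change because compound 1 has a limit and not a number: the limit of > 100000 nM in this assay, at which 2 of the 4 values shown sit.

The swap changes the aromatic ring, the oxygen and the bromine all at once, so the compounds shown cannot tell which of these matters. A plain phenoxy group, an amine at the same carbon, or a longer chain carrying the 4-bromophenoxy would help to separate them.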